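This account rests on a few compounds, and the source may have more. Where it says the series, first, only, none or still open, it means among the compounds named here.

Working notes on a series with a shared core. Compound 1 `COc1ccc(-c2c(C)nc3c(N4CC[C@@H](NC(C)=O)C4)cc(C)nn23)cc1F`, compound 2 `CC(=O)N[C@@H]1CCN(c2cc(C)nn3c(-c4cccc(S(=O)(=O)N(C)C)c4)c(C)nc23)C1` and compound 3 `COc1ccc(-c2c(C)nc3c(N4CC[C@@H](NC(=O)NC(C)C)C4)cc(C)nn23)cc1OC` have each been run in an ADME assay on microsomes from liver (Homo sapiens) for metabolic stability, read by LC-MS, with NADPH named in the record, with a stated time of 60 min, tested at 1 uM, in the absence of a further agent; a lower number here means that less of the compound is left, a higher number that more of the compound is left. For compound 1 the result is a limit of the assay rather than a number, > 95%. Compound 2 likewise returns only a limit, > 95%. Compound 3 too reaches a limit and no numerical value, > 95%. Compound 3 therefore stands together with the other two at the ceiling of the read-out, as summarised by the limit of > 95% in this assay, at which 3 of the 3 values shown sit. Going by the values given here, no step between two measured compounds is available, so the series itself gives no guide to how a change on the saturated ring carbon moves this assay.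

Compound 4 `COc1ccc(-c2c(C)nc3c(N4CC[C@@H](O)C4)cc(C)nn23)cc1OC` is not yet measured. It differs from compound 3 by hydroxy in place of (isopropylcarbamoyl)amino on a saturated ring carbon. Among the compounds with values here, with no measured step to lean on, the expected step from compound 3 to compound 4 in this assay is a number at least 5 percentage points lower from compound 3 to compound 4 (that floor lies within the scatter), which is taken as none beyond the scatter, with a slight downward lean. Compound 4 is accordingly estimated at 90%, within 72% to 99%, with a fair chance that only a limit is returned again.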

Compound 4, percent of the compound remaining: > 95%
Compound 4 gave a limit, no number (the forecaster's own chance of this, stated with the estimate: 55%); at least 5 percentage points between middle value and limit.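

Compound 3 and compound 4 each return only a limit in this assay, so no step can be read between them: the limit of > 95% in this assay, at which 4 of the 4 values shown sit. The compounds shown leave open whether any change on the saturated ring carbon moves this assay at all.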